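The source may hold more compounds than are shown below. What is called first, only, known or untested is meant among the compounds shown, and "the series" means these compounds.

Measured compounds in a physicochemical assay for acid dissociation:
- compound 1 `COc1ccc(-c2ccc3c(NCCCNCc4cc(F)ccc4OC)ccnc3c2)cc1`: 9.47
- compound 2 `COc1ccc(F)cc1CNCCCNc1ccnc2cc(-c3ccc(C(F)(F)F)cc3)ccc12`: 9.47
- compound 3 `COc1ccc(F)cc1CNCCCNc1ccnc2cc(-c3cccc4ccccc34)ccc12`: not yet measured

Compound 2 stands level with compound 1 at the digits reported; the step of no change at the digits printed from compound 1 to compound 2 (within the scatter) lies within the usual scatter, so the two values show no difference that can be read as a change.

The step to compound 3 is naphthalen-1-yl in place of 4-(trifluoromethyl)phenyl on an aromatic carbon. Among the measured compounds shown here, the only measured step that bears on it is the change at the same place from compound 1 to compound 2, where a trifluoromethyl replaced a methoxy on the distal aryl ring and no change at the digits printed from compound 1 to compound 2 (within the scatter) followed. That earlier exchange on the same aryl ring left the read-out unchanged, and the present exchange is again confined to that ring, with no change in hydrogen-bond donors or acceptors as counted. On that single precedent, the step of no change at the digits printed from compound 2 to compound 3 (within the scatter) is expected to be none beyond the scatter. For the measured compounds named here, compound 3 is therefore estimated at 9.47, with a range from 9.15 to 9.8; the range is widened somewhat because only one step, no change at the digits printed from compound 1 to compound 2 (within the scatter), informs it.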

Compound 3, acid dissociation constant: 9.47
Estimate against measurement, compound 3: no gap at the digits printed, within the range that was stated.
By their numbers in this assay, from the lowest: compounds 1, 2 and 3 (each within the scatter of the next).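

In this assay, replacing the substituted phenyl at this position with a fused aromatic group gives no change at the digits printed from compound 2 to compound 3 (within the scatter) and, against the methoxy-bearing member of the series, no change at the digits printed from compound 1 to compound 3 (within the scatter). The earlier comparison covered only an exchange of one substituent on a single aromatic ring, whereas naphthalen-1-yl brings two six-membered aromatic rings of carbon only in place of one, and the read-out for compounds 1, 2 and 3 still shows no difference that can be read as a change, so at this position it does not separate these three groups, including across the change in ring count. The series offers no independent measurement that would account for this level read-out.

As far as these compounds go, compounds 1, 2 and 3 differ only at this one position and carry only carbon-ring aryl groups there, so it remains open whether a pyridine ring, or an amine or a carboxylic acid on the aryl group, would leave this assay level. The shared remainder of the structure is also untested by these comparisons, and a longer chain in place of the present one could give a different reading.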